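This account rests on a few compounds, and the source may have more. Where it says the series, first, only, none or still open, it means among the compounds named here.

Measured so far in an assay on isolated protein for inhibition of protein kinase C zeta type (Homo sapiens), read by mobility shift assay, tested at 30 uM; on this read-out lower numbers stand for less inhibition and higher numbers for more inhibition at the one concentration tested (going by the name of the read-out):

compound 1 `Cc1cc2nn(-c3ccccc3)c(N)c2c(=O)[nH]1` — -49%
compound 2 `Nc1c2c(=O)[nH]c(-c3ccccc3)cc2nn1-c1ccccc1` — -163%

Both numbers are negative, so neither compound shows inhibition on this read-out; the read-out instead runs the other way at the single concentration tested. Going by the values given here, compound 2 holds the lowest of the two numbers: the one measured step, a number 114 percentage points lower from compound 1 to compound 2 (beyond the scatter), sets it well apart from compound 1, beyond the scatter.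

Compound 3 `Nc1c2c(=O)[nH]c(-c3ccccn3)cc2nn1-c1ccccc1` is the next member to be measured. It differs from compound 2 by pyridin-2-yl in place of phenyl on an aromatic carbon.

Among the compounds with values here, no measured step covers this kind of change. Within the data shown here, the only step in hand exchanges methyl for phenyl at the same position and is large in the downward direction; it says nothing about replacing one six-membered aromatic ring by another that differs in a single ring atom. Among the measured compounds shown here, with no precedent, the working expectation is a step of modest size at most, a number 33 percentage points higher from compound 2 to compound 3 (beyond the scatter), in either direction, and nothing firmly beyond the scatter. Compound 3 is therefore estimated at -130%, with a range from -210% to -40%, drawn wide because compound 2 gives -163%, a number itself far from zero.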

Compound 3, a percentage reported as inhibition, at one concentration (the size of the read-out at that concentration, not a potency): 3%
Compound 3: the middle estimate sits 133 percentage points below what was measured; measured number outside the range, above it.
By their numbers in this assay, from the lowest: compound 2; then compound 1; then compound 3.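

In this assay, the aromatic carbon next to the ring nitrogen responds strongly to a single ring atom: phenyl and pyridin-2-yl both count 6 heavy atoms, yet the exchange gives a number 166 percentage points higher from compound 2 to compound 3 (beyond the scatter) and adds one hydrogen-bond acceptor. The step of a number 52 percentage points higher from compound 1 to compound 3 (beyond the scatter) shows that an aromatic ring at this place does not always lower the number, since pyridin-2-yl ends above methyl while phenyl ends below it. Compound 3 at 3% is the only one of the three with a positive number, but that number is small, so the change removes the strongly negative reading without yet giving clear inhibition at the one concentration tested.

No measurement at hand accounts for the size of this change, so the result stands as an observation only. Still open, from the compounds shown here alone, is whether any ring nitrogen gives the same result or only the arrangement in pyridin-2-yl does, which pyridin-3-yl, pyridin-4-yl or pyrimidin-2-yl at the same carbon would test, and whether an amine or a carboxylic acid on the phenyl ring would also shift the number upward.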